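Permeability across the thiazole alkyl variants of the series

The source may hold more compounds than are shown below. What is called first, only, known or untested is meant among the compounds shown, and "the series" means these compounds.

Measured so far:
compound 1 `CC(C)c1csc(-c2cccc(CN(C)c3ccc4[nH]nc(C(=O)O)c4c3)c2O)n1` — < 0.05 10^-6 cm/s
compound 2 `Cc1nc(-c2cccc(CNc3ccc4[nH]nc(C(=O)O)c4c3)c2O)sc1C` — 3.8 10^-6 cm/s
compound 3 `Cc1csc(-c2cccc(CNc3ccc4[nH]nc(C(=O)O)c4c3)c2O)n1` — 4.5 10^-6 cm/s

In an ADME assay on MDCK cells (Canis lupus familiaris) for permeability, in the apical to basolateral direction (a higher number here means that the compound crosses the layer faster, a lower number that the compound crosses the layer more slowly), compound 1 gives only a limit, < 0.05 10^-6 cm/s. Compound 3 sits highest of the two numbers, with compound 2 nearest at 3.8 10^-6 cm/s; the step of a 1.2-fold higher number from compound 2 to compound 3 (0.07 log units; within the scatter) lies within the scatter. Compound 4 `CC(C)c1csc(-c2cccc(CNc3ccc4[nH]nc(C(=O)O)c4c3)c2O)n1` has not been measured in this assay. It differs from compound 3 by isopropyl in place of methyl on an aromatic carbon. For the measured compounds named here, the one measured step on the same ring, a 1.2-fold higher number from compound 2 to compound 3 (0.07 log units; within the scatter), shows that a change of alkyl on this ring moved the number little, so for compound 4 no step beyond the scatter is expected in either direction. The expected step is a 1.1-fold lower number from compound 3 to compound 4 (0.05 log units; within the scatter), giving an estimate for compound 4 of 4 10^-6 cm/s, between 1.5 10^-6 cm/s and 9 10^-6 cm/s.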

Compound 4, apparent permeability in the MDCK assay: 1.5 10^-6 cm/s
For compound 4 the middle estimate is 2.7-fold (0.43 log units) above the measured one; low and high end bracket the measured number.
By their numbers in the MDCK assay, from the lowest: compound 4; then compounds 2 and 3 (each within the scatter of the next). At a limit, below all of these: compound 1.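

At this position, on the aromatic carbon next to the ring nitrogen, alkyl size does register in the MDCK assay: a 3.0-fold lower number from compound 3 to compound 4 (0.48 log units; beyond the scatter) and a 2.5-fold lower number from compound 2 to compound 4 (0.40 log units; beyond the scatter), both beyond the scatter, unlike the earlier step between the two smaller thiazoles. In a physicochemical assay for solubility, measured as kinetic solubility, at pH 7.4 (a higher number here means a more soluble compound, a lower number a less soluble compound), compound 3 gives 44000 nM and compound 4 gives 102000 nM, so the same change runs the other way there, a 2.3-fold higher number from compound 3 to compound 4 (0.37 log units; beyond the scatter). Compound 1 stands at a limit in the MDCK assay, so an at least 30-fold higher number from compound 1 to compound 4 (1.47 log units; beyond the scatter) is a bound for hydrogen in place of methyl on the nitrogen, not a measured size.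

Still open, going by these compounds, is whether the number in the MDCK assay follows alkyl size alone, or would shift likewise with a tert-butyl group or an ether chain at this carbon.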